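Phenyl Replaces Methoxynaphthyl on the Saturated Ring Carbon

The compounds below may be only part of what the source reports. "The series", "measured", "known", "first", "only" and "open" are said of these compounds alone.

Compound 1 `COc1cc(N2C(N)=C(C#N)C(c3ccc(OC)c4ccccc34)C3=C2CC(C)(C)CC3=O)cc(OC)c1OC`: in a functional assay on Ehrlich cells (Mus musculus) for cytotoxicity, tested at 10 ug/mL (on this read-out higher numbers stand for a stronger effect at the one concentration tested and lower numbers for a weaker effect), compound 1 gives 10%.
Compound 2 `COc1cc(N2C(N)=C(C#N)C(c3ccc(O)cc3)C3=C2CC(C)(C)CC3=O)cc(OC)c1OC`: in this assay compound 2 gives 10%.
Compound 3 `COc1cc(N2C(N)=C(C#N)C(c3c(OC)ccc4ccccc34)C3=C2CC(C)(C)CC3=O)cc(OC)c1OC`: in this assay compound 3 gives 0%.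

Compound 3 holds the lowest of the three numbers, yet both of its gaps to the other compounds lie within the scatter: a number 10 percentage points lower from compound 1 to compound 3 (within the scatter) and a number 10 percentage points lower from compound 2 to compound 3 (within the scatter). Compound 4 `COc1cc(N2C(N)=C(C#N)C(c3ccccc3)C3=C2CC(C)(C)CC3=O)cc(OC)c1OC` differs from compound 3 in one place: phenyl in place of 2-methoxynaphthalen-1-yl on a saturated ring carbon. Among the compounds with values here, no measured step exchanges a naphthyl group for a plain phenyl, so the only guidance comes from the changes already made at this saturated ring carbon, namely no change at the digits printed from compound 1 to compound 2 (within the scatter) together with the two steps onto compound 3, none of which moved the read-out beyond the scatter. Because a number 10 percentage points lower from compound 1 to compound 3 (within the scatter) and a number 10 percentage points lower from compound 2 to compound 3 (within the scatter) stayed within the scatter, one expects a number 5 percentage points higher from compound 3 to compound 4 (within the scatter), a step that again should not exceed it. Compound 4 is therefore estimated at 5%, with a range from 0% to 20%.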

Compound 4, a percentage reported as activity, at one concentration (the size of the read-out at that concentration, not a potency): 0%
The estimate for compound 4 lay 5 percentage points above the measured number; the range from low to high includes it.
By their numbers in this assay, from the lowest: compounds 3, 4, 1 and 2 (each within the scatter of the next).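

In this assay, within the data shown here, the exchange of 2-methoxynaphthalen-1-yl for phenyl on the saturated ring carbon gave no change at the digits printed from compound 3 to compound 4 (within the scatter), the first direct step at this position from a naphthyl group to a plain phenyl. Replacing hydroxy with hydrogen on an aromatic carbon gave a number 10 percentage points lower from compound 2 to compound 4 (within the scatter), and phenyl in place of 4-methoxynaphthalen-1-yl gave a number 10 percentage points lower from compound 1 to compound 4 (within the scatter), so neither removing the hydroxy group nor going from two aromatic rings to one moved the read-out beyond the scatter. Nothing available offers an explanation for these results.

The compounds shown leave open whether any group on this saturated ring carbon can carry the read-out beyond the scatter. An amine or a carboxylic acid on the phenyl ring would be one way of putting that question to the test.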